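The compounds below may be only part of what the source reports. "The series", "measured", "known", "first", "only" and "open" are said of these compounds alone.

Compound 1 `CCCCn1ccc(-c2ccc(Oc3ccnc(C)c3)cc2)c(C#N)c1=O` was tested in a functional assay on CHO cells for positive allosteric modulation of metabotropic glutamate receptor 2 (Homo sapiens), read by scintillation counting and GTPgammaS binding, with a stated time of 30 min (on this read-out higher numbers stand for larger maximal responses and lower numbers for smaller maximal responses), where compound 1 gives 243%. For the measured compounds named here, its only measured companion is compound 2 `Cc1cc(Oc2ccc(-c3ccn(CC4CC4)c(=O)c3C#N)cc2)ccn1`, and in this assay compound 2 gives 199%. The step of a number 44 percentage points lower from compound 1 to compound 2 (beyond the scatter) came with cyclopropyl in place of propyl on a saturated chain carbon bound to an aromatic nitrogen. On these two numbers compound 1 stands highest, with compound 2 nearest at a step beyond the scatter. Compound 3 `CCCCn1ccc(-c2ccc(Oc3ccnc(C)c3)cc2Cl)c(C#N)c1=O` has not yet been measured; it differs from compound 1 by chloro in place of hydrogen on an aromatic carbon. Going by the values given here, no measured step bears on such a change: the single step in hand alters the saturated chain carbon bound to an aromatic nitrogen and leaves the aromatic carbon untouched, so it gives no guide to direction. The expected step in this assay is therefore a number 13 percentage points lower from compound 1 to compound 3 (beyond the scatter), none beyond the scatter. Compound 3 is estimated at 230%, within a range from 170% to 290%.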

Compound 3, largest response reached (Emax), in percent of the reference or control that the assay uses: 187%
Compound 3: middle estimate off by 43 percentage points, on the high side; low and high end bracket the measured number.
By their numbers in this assay, from the lowest: compound 3; then compound 2; then compound 1.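

In this assay, for the compounds shown here, chloro in place of hydrogen on an aromatic carbon gave a number 56 percentage points lower from compound 1 to compound 3 (beyond the scatter), the only measured change at this place, which is ortho to a large group and meta to the (2-methylpyridin-4-yl)oxy group. It shows that this carbon is not indifferent to substitution: a single chlorine atom, with no ring and no hydrogen-bond donor or acceptor, moves the maximal response by a large step beyond the scatter, and compound 3 gives 187%. No evidence in hand tells why the response falls with this change.

As far as these compounds go, whether the fall belongs to chloro in particular or would follow with another group here, such as fluoro, methyl or methoxy, remains open. Also open, from the compounds shown here alone, is whether the step would hold with cyclopropyl on the saturated chain carbon bound to the aromatic nitrogen.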